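Chloro to fluoro exchange: notes toward compound 4

The compounds below may be only part of what the source reports. "The series", "measured", "known", "first", "only" and "open" are said of these compounds alone.

Three compounds of the series have been run in a functional assay on isolated protein for agonist activity at Free fatty acid receptor 1 (Homo sapiens), read by HTRF and inositol phosphate accumulation, with a stated time of 60 min; a lower number here means that less compound is needed, a higher number that more compound is needed for the effect. Compound 1 `O=C(O)CCCOc1ccc(-c2cc(OC(F)(F)F)ccc2F)cc1` gives 4220 nM in this assay. Compound 2 `Cc1ccc(Oc2cccc(-c3ccc(OCCCC(=O)O)cc3)c2)cc1` reaches only the limit of the assay, > 9950 nM, and no number. Compound 3 `Cc1cc(-c2cc(OC(F)(F)F)ccc2Cl)ccc1OCCCC(=O)O` gives 6720 nM in this assay. Among the two numbers, compound 3 carries the higher one, though its gap to compound 1 lies within the scatter, so no order between the two can be claimed. Compound 2 stands at the limit of > 9950 nM in this assay, at which 1 of the 3 values shown sits.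

Compound 4 `Cc1cc(-c2cc(OC(F)(F)F)ccc2F)ccc1OCCCC(=O)O` has not yet been measured. It differs from compound 3 in one place: fluoro in place of chloro on an aromatic carbon. Among the compounds with values here, no measured pair in the set isolates this change. Compound 1, which carries fluoro at this place, at 4220 nM sits close to compound 3, so the step is expected to stay small. The expected step is a 1.3-fold lower number from compound 3 to compound 4 (0.13 log units; within the scatter), toward a slightly lower number but not beyond the scatter. For compound 4 the estimate in this assay is 5000 nM, with a range from 2000 nM to 12000 nM.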

Compound 4, half-maximal effective concentration: 9260 nM
Beside the measured number, compound 4's estimate is 1.9-fold (0.27 log units) below it; the range from low to high includes it.
By their numbers in this assay, from the lowest: compounds 1, 3 and 4 (each within the scatter of the next, the first and the last beyond it). At a limit, above all of these: compound 2.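

The fluoro in place of chloro exchange, on an aromatic carbon ortho to a large group and para to a trifluoromethoxy group, now has a direct pair, and with the methyl present the two halogens cannot be told apart (a 1.4-fold higher number from compound 3 to compound 4 (0.14 log units; within the scatter)). Within the data shown here, with fluoro held constant, methyl in place of hydrogen on an aromatic carbon gives the one step here that passes the scatter, and it is modest (a 2.2-fold higher number from compound 1 to compound 4 (0.34 log units; beyond the scatter)). Nothing measured for these compounds gives a cause for either step.

Going by these compounds, whether the methyl step holds with chloro in place of fluoro remains open. Also open, on these data alone, is how a methoxy group, a nitrile or an amine would compare with the methyl at that carbon.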